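Moving the Aryl Substituent in a Muscle Tissue Assay

This account rests on a few compounds, and the source may have more. Where it says the series, first, only, none or still open, it means among the compounds named here.

compound 1, `COC(=O)C1=C(C)N=C(C)/C(=C(\O)OC)C1c1ccc(Cl)cc1`: 8130 nM
compound 2, `COC(=O)C1=C(C)N=C(C)/C(=C(\O)OC)C1c1cccc(O)c1`: 1000 nM
compound 3, `COC(=O)C1=C(C)N=C(C)/C(=C(\O)OC)C1c1ccccc1I`: 46.8 nM

In a functional assay (muscle tissue) with Cavia porcellus as the target (a higher number here means that more compound is needed for the effect, a lower number that less compound is needed), compound 1 gives the highest of the three numbers. Its nearest neighbour is compound 2, reached by an 8.1-fold lower number from compound 1 to compound 2 (0.91 log units; beyond the scatter); the furthest is compound 3, reached by a 170-fold lower number from compound 1 to compound 3 (2.24 log units; beyond the scatter). Between the two other compounds the step is a 21-fold lower number from compound 2 to compound 3 (1.33 log units; beyond the scatter).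

Compound 4 `COC(=O)C1=C(C)N=C(C)/C(=C(\O)OC)C1c1cccc(Br)c1` differs from compound 1 in one place: 3-bromophenyl in place of 4-chlorophenyl on a saturated ring carbon. Among the measured compounds shown here, no measured step shows exactly this exchange. The step from compound 1 to compound 2 also replaces the 4-chlorophenyl with a group carrying its substituent at the 3-position and lowers the number modestly. The step from compound 1 to compound 3 keeps a halogen on the ring but places it at the 2-position and lowers the number by a large margin. Both steps point downward, so a lower number is expected for compound 4, most likely of modest size, estimated at a 9.0-fold lower number from compound 1 to compound 4 (0.96 log units; beyond the scatter). Compound 4 is therefore expected to give about 900 nM in this assay, with a range from 200 nM to 4000 nM.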

Compound 4, half-maximal effective concentration: 1.29 nM
The estimate for compound 4 lay 700-fold (2.84 log units) above the measured number; the measured number lies below the stated range.
By their numbers in this assay, from the lowest: compound 4; then compound 3; then compound 2; then compound 1.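

In this assay, among the compounds shown here, compound 4 has the lowest number of the four, well below both the compound with the 4-chlorophenyl group (a 6300-fold lower number from compound 1 to compound 4 (3.80 log units; beyond the scatter)) and the one with the 2-iodophenyl group (a 36-fold lower number from compound 3 to compound 4 (1.56 log units; beyond the scatter)), so a halogen on this phenyl ring does not by itself give a low number, and its identity or place matters greatly. For the compounds shown here, the exchange of bromo for hydroxy on an aromatic carbon (a 780-fold lower number from compound 2 to compound 4 (2.89 log units; beyond the scatter)) adds what the earlier compounds could not show: with the substituent at the 3-position in both compounds, the group itself still changes the number by a large margin. The data shown offer no measurement that explains why this exchange has so large an effect.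

The step from compound 1 to compound 4 changes both the halogen and its place on the phenyl ring, so the compounds shown cannot separate these two contributions. On these data alone, it also remains open how chloro, iodo, an amine or a carboxylic acid would behave on the aromatic carbon that carries the bromo in compound 4.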